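Swapping (Propylsulfonyl)amino for Pyridin-3-yl on Compound 2

The source may report more compounds than this note shows. Statements on the series, on what has been measured and on what is new or still open speak of the compounds shown alone.

Compound 1 `COc1c(C)ccc2c1CCC2c1ncc[nH]1`: > 10000 nM
Compound 2 `CCCS(=O)(=O)Nc1cccc2c1CCC2c1ncc[nH]1`: > 10000 nM
Compound 3 `CS(=O)(=O)Nc1c(Cl)ccc2c1CCCC2c1ncc[nH]1`: > 10000 nM

Of the compounds shown here, three have been tested in a functional assay on CHO cells for agonist activity at Alpha-1B adrenergic receptor (Homo sapiens), read by FLIPR and calcium flux; on this read-out higher numbers stand for an effect only at larger amounts of compound and lower numbers for an effect already at smaller amounts. In this assay compound 1 gives > 10000 nM, which is a limit of the assay and not a number. Compound 2 gives > 10000 nM, again a limit. Compound 3 gives > 10000 nM, also a limit. Compound 2 therefore stands nowhere in particular among the numbers shown: every value sits at the limit of > 10000 nM in this assay, at which 3 of the 3 values shown sit, and no compound can be placed above or below another.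

Compound 4 `c1cncc(-c2cccc3c2CCC3c2ncc[nH]2)c1` is not yet measured. It differs from compound 2 in one place: pyridin-3-yl in place of (propylsulfonyl)amino on an aromatic carbon. Among the compounds with values here, no step between two measured compounds is available, so nothing shows how much this assay responds to any change on the shared core. With all three measured compounds at the limit, the most that can be expected is that compound 4 stays at or near the limit as well; a move beyond the scatter in either direction cannot be ruled out, but nothing supports it.

The step of a number no higher from compound 2 to compound 4 (the limit leaves the size open) is expected to be none beyond the scatter. Compound 4 is estimated at 10000 nM, with a range from 2000 nM to 50000 nM.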

Compound 4, half-maximal effective concentration: > 10000 nM
Compound 4: a limit, no number; the forecaster's own chance of this, stated with the estimate: 70%; the middle value lies on the limit itself.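

Compound 4 gives > 10000 nM, which is a limit of the assay and not a number. Compound 2 also stands at a limit, so no step can be read between compound 2 and compound 4. All the compounds shown stand at the same point: the limit of > 10000 nM in this assay, at which 4 of the 4 values shown sit.

The compounds shown leave open whether any change on the shared core would give a readable value in this assay.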